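Swapping an Aryl Ether for a Benzyl Group

A few compounds are considered here, and "the series" means these few. Any claim that something is new, unique, unknown or untested is made for them only; others in the source may bear on it.

Measured compounds:
- Compound 1 `O=C(O)CC/C=C\CC1COC(c2ccc(Cl)cc2Cl)OC1c1cccnc1` gives 42 nM in an assay for inhibition of Thromboxane-A synthase (Homo sapiens), using microsomes; on this read-out higher numbers stand for weaker inhibition and lower numbers for stronger inhibition
- Compound 2 `O=C(O)CC/C=C\CC1COC(c2ccco2)OC1c1cccnc1` gives 164 nM in this assay
- Compound 3 `COc1ccc(OC(C)(C)C2OCC(C/C=C\CCC(=O)O)C(c3cccnc3)O2)cc1` gives 41 nM in this assay

Compound 3 has the lowest number of the three, yet its gap to compound 1 lies within the scatter, so the two cannot be ranked; only compound 2 stands apart as a weaker inhibitor. For the measured compounds named here, the one step available, a 3.9-fold higher number from compound 1 to compound 2 (0.59 log units; beyond the scatter), concerns the group on a saturated ring carbon, a different place from the one changed here.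

Compound 4 `CC(C)(Cc1ccc(F)cc1)C1OCC(C/C=C\CCC(=O)O)C(c2cccnc2)O1` differs from compound 3 by 4-fluorobenzyl in place of 4-methoxyphenoxy on a saturated chain carbon bound to two saturated chain carbons and a saturated ring carbon. Going by the values given here, no measured step touches this place, so the step from compound 1 to compound 2 bears on it only loosely, as a sign that swapping one aromatic group for another can shift the number modestly.

With that in mind, compound 4 is expected to land close to compound 3, with the step of a 1.2-fold higher number from compound 3 to compound 4 (0.09 log units; within the scatter) estimated as within the scatter. Compound 4 is therefore estimated at 50 nM, with a range from 18 nM to 140 nM in this assay.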

Compound 4, half-maximal inhibitory concentration: 45 nM
Beside the measured number, compound 4's estimate is 1.1-fold (0.05 log units) above it, within the range that was stated.
By their numbers in this assay, from the lowest: compounds 3, 1 and 4 (each within the scatter of the next); then compound 2.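

In this assay, 4-fluorobenzyl and 4-methoxyphenoxy on this saturated chain carbon cannot be told apart, with a 1.1-fold higher number from compound 3 to compound 4 (0.04 log units; within the scatter). The exchange takes away both oxygen atoms of the leaving group, and with them its 2 hydrogen-bond acceptors, and brings in a fluorine, so in this pair the number does not depend on those oxygens being present. No measurement on hand explains why the two groups give such similar numbers.

Both groups carry one six-membered aromatic ring of carbon only, so the compounds shown leave open whether an aromatic ring is needed at this place at all. A small group without a ring, such as a methyl or an amine, on the same carbon would test that, as would a longer chain between this carbon and the ring.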